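Series notes on four amides; compound 4 still open

The source may report more compounds than this note shows. Statements on the series, on what has been measured and on what is new or still open speak of the compounds shown alone.

Compound 1 `C=CC(=O)N1CCCC(n2nc(-c3ccc(Oc4ccccc4)cc3)cc2C(=O)O)C1`, compound 2 `C/C=C/C(=O)N1CCCC(n2nc(-c3ccc(Oc4ccccc4)cc3)cc2C(=O)O)C1` and compound 3 `C/C=C/C(=O)N1CCCC(n2nc(-c3ccc(Oc4ccccc4)cc3)cc2CO)C1` share one core and have each been run in a functional assay on JeKo-1 cells (Homo sapiens) for inhibition, read by luminescence and CellTiter-Glo, with a stated time of 72 h; on this read-out higher numbers stand for weaker inhibition and lower numbers for stronger inhibition. In this assay compound 1 returns > 60000 nM, which is a limit of the assay and not a number. Compound 2 likewise returns only a limit, > 60000 nM. Compound 3 also gives a limit, > 60000 nM. All three values thus sit at the limit of > 60000 nM in this assay, at which 3 of the 3 values shown sit.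

Compound 1 differs from compound 2 by vinyl in place of prop-1-en-1-yl on a carbonyl carbon, and the step that the two limits leave unreadable from compound 2 to compound 1 cannot be sized because the limit of > 60000 nM in this assay, at which 3 of the 3 values shown sit, covers both ends of it. Compound 3 differs from compound 2 in the core by hydroxymethyl in place of carboxy on an aromatic carbon; the step that the two limits leave unreadable from compound 2 to compound 3 is unreadable for the same reason, since the limit of > 60000 nM in this assay, at which 3 of the 3 values shown sit, holds both values.

Compound 4 `C=CC(=O)N1CCCC(n2nc(-c3ccc(Oc4ccccc4)cc3)cc2CO)C1` has not been measured. It differs from compound 3 by vinyl in place of prop-1-en-1-yl on a carbonyl carbon. This is the same change as that from compound 2 to compound 1, at a place described in identical words: a carbonyl carbon whose other neighbour is an amide-type nitrogen in a ring. Within the data shown here, the one measured instance, a step that the two limits leave unreadable from compound 2 to compound 1, gave no readable size, so nothing points to a gain.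

The step from compound 3 to compound 4 in this assay is expected to be a step that the limit leaves unreadable from compound 3 to compound 4, resting on compound 3 standing at > 60000 nM and on the unreadable step that the two limits leave unreadable from compound 2 to compound 1. Compound 4 is estimated at 80000 nM, within 30000 nM to 200000 nM, and is expected most often to be reported as a limit again.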

Compound 4, half-maximal inhibitory concentration: 11900 nM
Compound 4: the middle estimate sits 6.7-fold (0.83 log units) above what was measured, outside the stated range (below it).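

In this assay, vinyl in place of prop-1-en-1-yl on a carbonyl carbon gives an at least 5.0-fold lower number from compound 3 to compound 4 (0.70 log units; beyond the scatter), so on the core bearing hydroxymethyl this change moves the number beyond the scatter. The same change on the core bearing carboxy, from compound 2 to compound 1, cannot be read, and neither can hydroxymethyl in place of carboxy from compound 2 to compound 3, as both ends of each step are limits of the assay and not numbers: the limit of > 60000 nM in this assay, at which 3 of the 4 values shown sit. With vinyl held constant, hydroxymethyl in place of carboxy gives an at least 5.0-fold lower number from compound 1 to compound 4 (0.70 log units; beyond the scatter), so a readable value appears only where vinyl and hydroxymethyl occur together, and the series shows neither that the vinyl change carries over to the carboxy core nor that it fails there.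

Open, as far as these compounds go, is whether another group on the aromatic carbon, such as an aminomethyl or a methyl ester, would keep a readable value alongside vinyl. Also open, from the compounds shown here alone, is how a longer chain on the carbonyl carbon, or an amine carried on that chain, would read on the hydroxymethyl core of compound 4.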